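Acrylonitrile series: pyrrole to furan at the vinyl position

The source may report more compounds than this note shows. Statements on the series, on what has been measured and on what is new or still open speak of the compounds shown alone.

Measured so far in a functional assay on NCI-H460 cells (Homo sapiens) for inhibition, read by MTT assay, with a stated time of 72 h; a lower number here means a stronger inhibitor of growth, a higher number a weaker inhibitor of growth:
compound 1, `N#C/C(=C\c1c(F)c(F)c(F)c(F)c1F)C(=O)c1ccc[nH]1`: 31000 nM
compound 2, `N#C/C(=C\c1c[nH]c2ccccc12)C(=O)c1c[nH]c2ccccc12`: 7600 nM
compound 3, `COc1ccc(CNC(=O)/C(C#N)=C/c2ccc[nH]2)cc1`: > 50000 nM

Compound 3 stands apart from the other two: its result in this assay is a limit of the assay and not a number, as noted in the limit of > 50000 nM in this assay, at which 1 of the 3 values shown sits. Compound 1 and compound 2 each give a number, and both are weak growth inhibitors. Among the compounds with values here, no step between measured compounds with a single change is available, so nothing in this set tells how large any one change is.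

Compound 4, `COc1ccc(CNC(=O)/C(C#N)=C/c2ccco2)cc1`, is the next compound to be measured in this assay. It differs from compound 3 in one place: furan-2-yl in place of 1H-pyrrol-2-yl on a double-bonded chain carbon bound to a double-bonded chain carbon. The amide side of the molecule is kept.

With compound 3 known only as a limit, the step from compound 3 to compound 4 is expected to be small or none beyond the scatter, a step that the limit leaves unreadable from compound 3 to compound 4. Compound 4 is therefore estimated at 60000 nM in this assay, with a range from 15000 nM to 250000 nM, and a real chance that it too returns only a limit.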

Compound 4, concentration for 50% growth inhibition: 32000 nM
Compound 4: the middle estimate sits 1.9-fold (0.27 log units) above what was measured; the measured number falls inside the stated range.
By their numbers in this assay, from the lowest: compound 2; then compounds 1 and 4 (each within the scatter of the next). At a limit, above all of these: compound 3.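

In this assay, within the data shown here, furan-2-yl in place of 1H-pyrrol-2-yl on a double-bonded chain carbon bound to a double-bonded chain carbon gives an at least 1.5-fold lower number from compound 3 to compound 4 (0.19 log units; that floor lies within the scatter), the only single change readable so far. The value of compound 3, > 50000 nM, is a limit of the assay and not a number. Compound 4 does give a number with the amide side kept, but the size of this change can be stated only as a floor because one end of the step is a limit: the limit of > 50000 nM in this assay, at which 1 of the 4 values shown sits.

The compounds shown leave open whether the leaving hydrogen-bond donor or the change of ring hetero atom matters here, which 1-methylpyrrol-2-yl at this place would help to separate. Also open, on these data alone, are how thiophen-2-yl would read there and what an amine or a carboxylic acid on the amide side would do.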